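Replacing the cyano group of compound 2

The source may hold more compounds than are shown below. What is called first, only, known or untested is meant among the compounds shown, and "the series" means these compounds.

compound 1 `FC(F)(F)c1cccc(-c2nc3cnc(Nc4ccccn4)cc3[nH]2)c1` gives 45%
compound 2 `N#Cc1ccc(Nc2cc3[nH]c(-c4cccc(C(F)(F)F)c4)nc3cn2)nc1` gives 49%

In an ADME assay on microsomes from liver (Rattus norvegicus) for metabolic stability, read by LC-MS, with a stated time of 30 min, tested at 0.1 uM (on this read-out higher numbers stand for a more stable compound and lower numbers for a less stable compound), compound 2 gives 49% and cannot be told apart from compound 1 on these numbers. Compound 3 `CN1CCN(c2ccc(Nc3cc4[nH]c(-c5cccc(C(F)(F)F)c5)nc4cn3)nc2)CC1` has not yet been measured. It carries 4-methylpiperazin-1-yl in place of cyano on an aromatic carbon. Among the compounds with values here, the only measured step that bears on this change is a number 4 percentage points higher from compound 1 to compound 2 (within the scatter) and it stays within the scatter. That step exchanged only hydrogen and cyano, so it offers weak guidance for a much larger group that brings in a non-aromatic ring. With so little evidence, a moderate fall is expected, an estimated a number 14 percentage points lower from compound 2 to compound 3 (beyond the scatter) that could prove larger or smaller. In this assay compound 3 is expected to give 35% within a range of 15% to 55% as an estimate.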

Compound 3, percent of the compound remaining: 46%
Beside the measured number, compound 3's estimate is 11 percentage points below it; measured number inside the range.
By their numbers in this assay, from the lowest: compounds 1, 3 and 2 (each within the scatter of the next).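

In this assay, a far larger group with a six-membered non-aromatic ring replaces the small cyano on this aromatic carbon and gives a number 3 percentage points lower from compound 2 to compound 3 (within the scatter) at this site. Measured against plain hydrogen, the same 4-methylpiperazin-1-yl group gives a number 1 percentage points higher from compound 1 to compound 3 (within the scatter) in the same series, so among these three compounds the read-out cannot separate hydrogen, cyano and 4-methylpiperazin-1-yl, even though they differ greatly in size. Nothing shown here explains why these three numbers sit so close together. On these data alone, it remains open whether this insensitivity extends to other kinds of group at the same carbon, such as a carboxylic acid or a longer chain ending in an amine. The compounds shown also cannot tell whether changes elsewhere on the shared core would move this read-out beyond the usual scatter.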